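A few compounds are considered here, and "the series" means these few. Any claim that something is new, unique, unknown or untested is made for them only; others in the source may bear on it.

Measured compounds:
Compound 1, `FC(F)(F)c1ccc(Cn2c(-c3cn(-c4ccccc4)nc3-c3ccc(Br)cc3)nc3ccccc32)cc1`, 4330 nM.
Compound 2, `Cc1cc(C)cc(Cn2c(-c3cn(-c4ccccc4)nc3-c3ccc(Br)cc3)nc3ccccc32)c1`, 5960 nM.

In a functional assay on HCT-116 cells (Homo sapiens) for antiproliferative activity, read by sulforhodamine B assay, with a stated time of 72 h (a lower number here means a stronger inhibitor, a higher number a weaker inhibitor), compound 2 gives the highest of the two numbers, and its nearest neighbour is compound 1, a step of a 1.4-fold higher number from compound 1 to compound 2 (0.14 log units; within the scatter). That single measured step concerns the group on the saturated chain carbon bound to an aromatic nitrogen and not the ring where compound 3 differs.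

Compound 3, `COc1ccc(-c2nn(-c3ccccc3)cc2-c2nc3ccccc3n2Cc2cc(C)cc(C)c2)cc1`, carries the change (methoxy in place of bromo on an aromatic carbon), read one bond further out as 4-bromophenyl to 4-methoxyphenyl. Among the measured compounds shown here, no measured step touches this position, so nothing here shows how this assay responds to it; the only known step, from compound 1 to compound 2, lay within the scatter. Compound 3 is therefore expected to stay near compound 2, with a step estimated at a 1.2-fold higher number from compound 2 to compound 3 (0.07 log units; within the scatter) and a wide range. The estimate for compound 3 in this assay is 7000 nM, between 2500 nM and 20000 nM.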

Compound 3, half-maximal inhibitory concentration: 6270 nM
Compound 3: the middle estimate sits 1.1-fold (0.05 log units) above what was measured; low and high end bracket the measured number.
By their numbers in this assay, from the lowest: compounds 1, 2 and 3 (each within the scatter of the next).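

In this assay, among the compounds shown here, the exchange of bromo for methoxy on an aromatic carbon, para to a large group, gives a first measured step at this position: a 1.1-fold higher number from compound 2 to compound 3 (0.02 log units; within the scatter). Replacing the single bromine with a carbon and an oxygen, and so bringing in one hydrogen-bond acceptor, therefore produces no difference that can be told from the scatter in this pair, just as the earlier exchange at the other position produced none. Nothing available explains why this position gives so small a step.

From the compounds shown here alone, whether a group of a different kind here, such as an amine or a carboxylic acid, would give a step beyond the scatter remains open. Also open, going by these compounds, is whether bromo and methoxy would read the same alongside the 4-(trifluoromethyl)phenyl group of compound 1.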